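The source may report more compounds than this note shows. Statements on the series, on what has been measured and on what is new or still open speak of the compounds shown alone.

Going by the values given here, in a functional assay on SGC-7901 cells (Homo sapiens) for antiproliferative activity, read by sulforhodamine B assay, with a stated time of 72 h (on this read-out higher numbers stand for weaker inhibition and lower numbers for stronger inhibition), only two compounds have been measured so far. Compound 1 `NC(=S)N/N=C/c1nc2ccccc2s1` gives no number, only a limit of the assay, > 100000 nM. Among the compounds with values here, compound 2 `CN(C)C(=S)N/N=C/c1cnc2ccccc2n1` gives 170 nM, which is the only true number available, so there is no second number against which to rank it. Compound 3 `NC(=S)N/N=C/c1cnc2ccccc2n1` keeps the core of compound 2 and alters a single group: amino in place of dimethylamino on a thiocarbonyl carbon. Within the data shown here, no measured pair isolates this change, so what follows is a judgement rather than a reading from a matched comparison. In this assay, a clear weakening is expected, with a step well beyond the usual scatter, though its size is quite uncertain. Compound 2 at 170 nM leaves much room for such a loss. A reading for compound 3 at the end of the measurable range would not be a surprise. The expected change is a 35-fold higher number from compound 2 to compound 3 (1.55 log units; beyond the scatter). For compound 3 the estimated value is 6000 nM, with an expected range of 600 nM to 100000 nM.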

Compound 3, half-maximal inhibitory concentration: > 100000 nM
Compound 3 gave a limit, no number; the forecaster's own chance of this, stated with the estimate: 25%; at least 16-fold (1.22 log units) between middle value and limit.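

In this assay, the change to amino in place of dimethylamino on a thiocarbonyl carbon now has a matched pair behind it, and it brings an at least 580-fold higher number from compound 2 to compound 3 (2.76 log units; beyond the scatter), a large step. Compound 2 alone could not show whether this position mattered, but with the core held constant, this one pair shows that it does: the compound with dimethylamino has a measurable value, while the compound with amino does not. The size of the step is a lower bound rather than a measurement, because the reading for compound 3 is a limit of the assay and not a number: the limit of > 100000 nM in this assay, at which 2 of the 3 values shown sit.

The compounds shown leave open how far compound 3 really lies from compound 2, and whether methylamino, which keeps one of the two methyl groups, would read closer to one or the other. From the compounds shown here alone, it is also open whether diethylamino or a piperidine ring on the same thiocarbonyl carbon would keep, improve on or lose the value of compound 2, 170 nM.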